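Ethyl for dichlorophenyl on the piperazine: second core

This account rests on a few compounds, and the source may have more. Where it says the series, first, only, none or still open, it means among the compounds named here.

Compound 1 `Cc1nc([N+](=O)[O-])cn1CC(O)CSC(=S)N1CCN(c2cccc(Cl)c2Cl)CC1` carries a dithiocarbamate link between the nitroimidazole propanol arm and the piperazine. In a toxicity assay on HeLa cells (Homo sapiens) for cytotoxicity, read by MTT assay, with a stated time of 24 h (on this read-out lower numbers stand for stronger inhibition and higher numbers for weaker inhibition), compound 1 gives 724000 nM. Compound 2 `CCN1CCN(C(=S)SCC(O)Cn2cc([N+](=O)[O-])nc2C)CC1` is the ethyl analogue of compound 1. In this assay compound 2 reaches only a limit of the assay, > 5000000 nM. The change is ethyl in place of 2,3-dichlorophenyl on an amine nitrogen in a ring and the step is an at least 6.9-fold higher number from compound 1 to compound 2 (0.83 log units; beyond the scatter); with one of the values being (the limit of > 5000000 nM in this assay, at which 1 of the 3 values shown sits), only a lower bound on the step is known.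

Compound 3 `Cc1nc([N+](=O)[O-])cn1CC(O)CN1CCN(c2cccc(Cl)c2Cl)CC1` has the piperazine attached directly to the propanol arm. In this assay compound 3 gives 3620000 nM, the higher of the two numbers for which a value rather than a limit was read. The difference between the two cores, that of compound 1 and that of compound 3, is not broken down here.

Compound 4 `CCN1CCN(CC(O)Cn2cc([N+](=O)[O-])nc2C)CC1` is the ethyl analogue of compound 3, the change being (ethyl in place of 2,3-dichlorophenyl on an amine nitrogen in a ring), the same change as from compound 1 to compound 2 at the same place. Since compound 3 already stands at 3620000 nM, a step of the size seen in an at least 6.9-fold higher number from compound 1 to compound 2 (0.83 log units; beyond the scatter) would be expected to carry compound 4 to a far higher number in this assay. Compound 4 is expected to show a 4.1-fold higher number from compound 3 to compound 4 (0.62 log units; beyond the scatter), resting on that earlier step. The estimate for compound 4 is 15000000 nM, between 4000000 nM and 60000000 nM.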

Compound 4, half-maximal inhibitory concentration: > 5000000 nM
Compound 4: a limit, no number (the forecaster's own chance of this, stated with the estimate: 85%); the middle value does not contradict the limit.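

In this assay compound 4 gives no number, only a limit of the assay, > 5000000 nM. On the core of compound 3, ethyl in place of 2,3-dichlorophenyl reads as an at least 1.3-fold higher number from compound 3 to compound 4 (0.14 log units; that floor lies within the scatter), so this step is known only as a floor, and the floor alone does not show a change on this core. The result is compatible with the change carrying over from the core of compound 1 to the core of compound 3, but it establishes neither that the step has the same size on both cores nor that it differs between them: the same change on two cores in this assay, an at least 6.9-fold higher number (0.83 log units; beyond the scatter) from compound 1 to compound 2 and an at least 1.3-fold higher number (0.14 log units; that floor lies within the scatter) from compound 3 to compound 4; the limit leaves it open whether they differ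

Still open, from the compounds shown here alone, are the true size of the step on either core and any order between the two ethyl compounds, since compound 2 and compound 4 both give limits rather than numbers: the limit of > 5000000 nM in this assay, at which 2 of the 4 values shown sit. Also open is how other groups on that amine nitrogen in a ring, such as a benzyl group, a longer alkyl chain or a phenyl ring without chlorine, would read on the two cores, and whether any of them would give a number in the range that can be read.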